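Furanylmethyl in Place of Cyclopentyl on the Amine Nitrogen

The source may hold more compounds than are shown below. What is called first, only, known or untested is meant among the compounds shown, and "the series" means these compounds.

Measured compounds:
compound 1 `CC(CNC1CCCC1)Oc1cccc2ccc(N)nc12` — 30 nM
compound 2 `COc1cccc(CNCC(C)Oc2cccc3ccc(N)nc23)c1` — 600 nM
compound 3 `CC(CNc1ccc2[nH]ncc2c1)Oc1cccc2ccc(N)nc12` — 8180 nM

In a functional assay on IMR-32 cells with melanin-concentrating hormone receptor 1 (Homo sapiens) as the target, read by fluorescence (on this read-out lower numbers stand for stronger inhibition and higher numbers for weaker inhibition), compound 1 gives the lowest number of the three; compound 2 lies clearly higher, beyond the scatter, and compound 3 higher still. Compound 4 `CC(CNCc1ccoc1)Oc1cccc2ccc(N)nc12` differs from compound 1 by (furan-3-yl)methyl in place of cyclopentyl on an amine nitrogen. Among the measured compounds shown here, no measured pair shows this exact exchange. The nearest guide is compound 2, which also carries an aromatic ring on the amine nitrogen and gives 600 nM, whereas compound 1 gives 30 nM. Because compound 2 sits at 600 nM, a weakening step is expected, a 5.0-fold higher number from compound 1 to compound 4 (0.70 log units; beyond the scatter), though smaller than that seen for compound 2. Compound 4 is therefore estimated at 150 nM, with a range from 50 nM to 600 nM.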

Compound 4, half-maximal inhibitory concentration: 100 nM
Beside the measured number, compound 4's estimate is 1.5-fold (0.18 log units) above it; low and high end bracket the measured number.
By their numbers in this assay, from the lowest: compound 1; then compound 4; then compound 2; then compound 3.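

With (furan-3-yl)methyl in place of cyclopentyl on the amine nitrogen, this assay shows a 3.3-fold higher number from compound 1 to compound 4 (0.52 log units; beyond the scatter), so this position admits an aromatic ring at a modest cost. Furan-3-yl in place of 3-methoxyphenyl gives a 6.0-fold lower number from compound 2 to compound 4 (0.78 log units; beyond the scatter), showing that the choice of aromatic ring on this chain also moves the number. Nothing measured here explains either step. The compounds shown leave open whether the ring or the added chain carbon accounts for the first step, which cyclopentylmethyl on the same nitrogen would separate.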